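Chain shortening in a pyridyl-oxadiazolyl ketone series

This account rests on a few compounds, and the source may have more. Where it says the series, first, only, none or still open, it means among the compounds named here.

Measured so far:
compound 1 `O=C(CCCCCCc1ccccc1)c1nnc(-c2ccncc2)o1`: 30 nM
compound 2 `O=C(CCCCCCCc1ccccc1)c1nnc(-c2ccccn2)o1`: 200 nM

In an assay on isolated protein for inhibition of liver carboxylesterase 1 (Homo sapiens), read by radioligand binding (a lower number here means a stronger inhibitor, a higher number a weaker inhibitor), compound 2 gives 200 nM and stands at the weaker end of the two numbers; compound 1 gives 30 nM, a gap beyond the scatter. Compound 3 `O=C(CCCCCc1ccccc1)c1nnc(-c2ccccn2)o1` differs from compound 2 as follows: phenyl in place of phenethyl on a saturated chain carbon, five bonds along the chain from a carbonyl carbon. Among the compounds with values here, no measured pair isolates this change, so the direction of the step is open; a modest step is expected, likely within or near the scatter. Compound 3 is expected at 150 nM (range 40 nM to 600 nM), which means an expected step of a 1.3-fold lower number from compound 2 to compound 3 (0.12 log units; within the scatter).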

Compound 3, half-maximal inhibitory concentration: 30 nM
Estimate against measurement, compound 3: 5.0-fold (0.70 log units) above; measured number below the stated range.
By their numbers in this assay, from the lowest: compounds 1 and 3 (each within the scatter of the next); then compound 2.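

In this assay, within the data shown here, phenyl in place of phenethyl on a saturated chain carbon, five bonds along the chain from a carbonyl carbon, gives a 6.7-fold lower number from compound 2 to compound 3 (0.82 log units; beyond the scatter), the first step to isolate a change at this place. Chain length here therefore matters, and the smaller group of this pair carries the lower number. Nothing at hand explains the size of this step.

As far as these compounds go, whether a still shorter chain, or an amine or carboxylic acid at the chain end, keeps this number remains open. Also open, from the compounds shown here alone, is whether the same change has a similar effect on the core of compound 1.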